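Ester to cyclopropylamide: expected effect on growth inhibition

This account rests on a few compounds, and the source may have more. Where it says the series, first, only, none or still open, it means among the compounds named here.

compound 1 `CCOC(=O)/C=C/c1ccncc1-c1ccc2[nH]ccc2c1`: > 10000 nM
compound 2 `CCOC(=O)/C=C/c1ccncc1-c1ccc2ccccc2c1`: 8320 nM
compound 3 `O=C(O)/C=C/c1ccncc1-c1ccc2cc[nH]c2c1`: > 10000 nM

Of the compounds shown here, three have been measured in a functional assay on MCF7 cells (Homo sapiens) for inhibition, read by sulforhodamine B assay, with a stated time of 72 h; a lower number here means a stronger inhibitor of growth, a higher number a weaker inhibitor of growth. Compound 1 `CCOC(=O)/C=C/c1ccncc1-c1ccc2[nH]ccc2c1` reaches only the limit of the measurement, > 10000 nM. Compound 3 `O=C(O)/C=C/c1ccncc1-c1ccc2cc[nH]c2c1` likewise gives only a limit, > 10000 nM. For the measured compounds named here, compound 2 `CCOC(=O)/C=C/c1ccncc1-c1ccc2ccccc2c1` is the one compound with a number, 8320 nM in this assay; the remainder of the set sits at the limit of > 10000 nM in this assay, at which 2 of the 3 values shown sit. Going by the values given here, no two measured compounds differ in a single place, so no measured step is available to calibrate any change.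

Compound 4 `O=C(/C=C/c1ccncc1-c1ccc2ccccc2c1)NC1CC1` has not yet been measured. It differs from compound 2 in one place: cyclopropylamino in place of ethoxy on a carbonyl carbon. Among the compounds with values here, nothing among the measured compounds shows what an exchange of this kind does in this assay. The expected step is small, a 1.7-fold lower number from compound 2 to compound 4 (0.22 log units; within the scatter), not clearly beyond the scatter in either direction. Compound 4 is expected to give 5000 nM in this assay, with a range from 1500 nM to 15000 nM.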

Compound 4, concentration for 50% growth inhibition: 6840 nM
Compound 4: the middle estimate sits 1.4-fold (0.14 log units) below what was measured, and the stated range covers the measured number.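

In this assay, for the compounds shown here, the exchange of ethoxy for cyclopropylamino on a carbonyl carbon supplies the first readable step, a 1.2-fold lower number from compound 2 to compound 4 (0.09 log units; within the scatter), and it gives this position its first calibration. This assay does not separate the ethyl ester from the cyclopropylamide, even though the exchange brings in a three-membered ring and a hydrogen-bond donor. Growth inhibition stays weak across the set shown: the limit of > 10000 nM in this assay, at which 2 of the 4 values shown sit.

From the compounds shown here alone, whether any group on this carbonyl carbon moves the number beyond the scatter remains open, for instance a morpholine amide, a dimethylamino group or a longer alkylamine chain. Also open, going by these compounds, is whether the same exchange reads alike on the core of compound 1, where the ester gives only a limit.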